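The source may hold more compounds than are shown below. What is called first, only, known or untested is meant among the compounds shown, and "the series" means these compounds.

In a functional assay on KB cells (Homo sapiens) for cytotoxicity (on this read-out lower numbers stand for stronger inhibition and higher numbers for weaker inhibition), two compounds have been measured so far. Compound 1 (`C/C=C/C(=O)OC1=CC(=O)c2ccccc2C1=O`) gives 64200 nM, the higher of the two numbers and therefore the weaker inhibition. Compound 2 (`Cc1ccc(S(=O)(=O)Oc2ccc3c(c2)C(=O)C=CC3=O)cc1`) gives 16400 nM, a lower number by more than the usual scatter. Compound 2 differs from compound 1 in more than one place, so this gap says little about a single change.

Compound 3 (`CC(=O)OC1=CC(=O)c2ccccc2C1=O`) has not yet been measured in this assay. It has methyl in place of prop-1-en-1-yl on a carbonyl carbon. The core of compound 1 is retained. For the measured compounds named here, no measured pair shows this change, so the expectation is weakly grounded, and no step beyond the scatter is expected. The estimated change is a 1.3-fold lower number from compound 1 to compound 3 (0.11 log units; within the scatter). For compound 3, the estimated value is 50000 nM, with an expected range of 15000 nM to 130000 nM.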

Compound 3, half-maximal inhibitory concentration: 38800 nM
For compound 3 the middle estimate is 1.3-fold (0.11 log units) above the measured one; low and high end bracket the measured number.
By their numbers in this assay, from the lowest: compound 2; then compounds 3 and 1 (each within the scatter of the next).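

Methyl in place of prop-1-en-1-yl on a carbonyl carbon gives a 1.7-fold lower number from compound 1 to compound 3 (0.22 log units; within the scatter) in this assay and provides the first comparison in this series that differs in one place. With the core of compound 1 retained, the read-out does not separate these two groups at this position, even though prop-1-en-1-yl brings a double bond outside aromatic rings and methyl does not. No measured evidence bears on why the two groups read alike.

A phenyl ring, a longer alkyl chain or an amine-bearing chain on the same carbonyl carbon would show whether this position responds to any change at all, since two small groups cannot settle that. Compound 2 (16400 nM) differs from compound 1 and compound 3 in more than one place, so its value cannot be assigned to any single change.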